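This account rests on a few compounds, and the source may have more. Where it says the series, first, only, none or still open, it means among the compounds named here.

In a functional assay for inhibition, with Rattus norvegicus as the target (on this read-out lower numbers stand for stronger inhibition and higher numbers for weaker inhibition), two compounds sharing the same core have been measured so far. Compound 1 `CC(C)(C)/N=c1\c(O)c(O)\c1=N/c1ccc(C#N)cc1`, with tert-butyl on a double-bonded nitrogen, gives 560 nM. Compound 2 `CC(C)C(C)/N=c1\c(O)c(O)\c1=N/c1ccc(C#N)cc1`, with 1,2-dimethylpropyl there instead, gives 1900 nM, the higher of the two numbers and therefore the weaker inhibition.

The next compound is compound 3 `CCC(CC)/N=c1\c(O)c(O)\c1=N/c1ccc(C#N)cc1`, which has pentan-3-yl in place of 1,2-dimethylpropyl on a double-bonded nitrogen. The two groups have the same atoms, joined differently.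

Among the measured compounds shown here, only one measured step bears on this change: a 3.4-fold higher number from compound 1 to compound 2 (0.53 log units; beyond the scatter). This modest step lies beyond the scatter and also involves a change of group on that nitrogen, so a further change there could shift the number. However, a single step cannot show which way pentan-3-yl will move it. A step no larger than that one is expected, quite possibly within the scatter, with no firm direction. The expected step is a 1.2-fold lower number from compound 2 to compound 3 (0.07 log units; within the scatter). For compound 3, the estimated value is 1600 nM, with an expected range from 550 nM to 4500 nM.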

Compound 3, half-maximal inhibitory concentration: 3340 nM
The estimate for compound 3 lay 2.1-fold (0.32 log units) below the measured number; the range from low to high includes it.
By their numbers in this assay, from the lowest: compound 1; then compounds 2 and 3 (each within the scatter of the next).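

Moving the same atoms from 1,2-dimethylpropyl to pentan-3-yl on the double-bonded nitrogen gives a 1.8-fold higher number from compound 2 to compound 3 (0.24 log units; within the scatter) in this assay, so this rearrangement does not separate the two groups on this read-out. Replacing tert-butyl with pentan-3-yl gives a 6.0-fold higher number from compound 1 to compound 3 (0.78 log units; beyond the scatter), a step that, like the one from tert-butyl to 1,2-dimethylpropyl, lies beyond the scatter, so among these three compounds tert-butyl alone stands apart, with the lowest number and thus the strongest inhibition. No measurement here explains why this position responds in this way.

These compounds leave open how the number would respond on that same nitrogen to a smaller group such as isopropyl, a ring such as cyclopentyl or cyclohexyl, or a chain carrying a hydroxyl group or an amine. All three also keep the same nitrile-bearing aromatic ring and the shared core, so they say nothing about how replacing the nitrile with an amide or a carboxylic acid would change the number.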